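A few compounds are considered here, and "the series" means these few. Any claim that something is new, unique, unknown or untested is made for them only; others in the source may bear on it.

Working notes on the series. Compound 1 `O=C1Oc2ccccc2N/C1=C\C(=O)c1ccncc1` serves as the reference point. In an ADME assay on Vero cells (Chlorocebus sabaeus) for cytotoxicity, read by MTT assay, with a stated time of 72 h (on this read-out lower numbers stand for higher toxicity in this test and higher numbers for lower toxicity in this test), compound 1 gives only a limit, > 1870000 nM. Compound 2 `O=C1/C(=C/c2ccccc2Cl)Oc2ccccc2N1Cc1ccccc1` has no result in this assay, "not determined" (no result reported). Compound 3 `O=C(NNC(=O)c1ccncc1)C(=O)Nc1ccc(Cl)cc1O` gives 1170000 nM in this assay. Among the measured compounds shown here, compound 1 thus sits at the limit of > 1870000 nM in this assay, at which 1 of the 3 values shown sits; no single number exists for it, and no step between measured compounds can be drawn from the data. Compound 4 `Cc1cccc(C(=O)/C=C2\Nc3ccccc3OC2=O)c1` is the next member: 3-methylphenyl in place of pyridin-4-yl on a carbonyl carbon. For the measured compounds named here, no measured step is available for this change, so the expected shift in this assay is none beyond the scatter. The estimate for compound 4 in this assay is 1500000 nM, with a range of 600000 nM to 4000000 nM, an expected at least 1.2-fold lower number from compound 1 to compound 4 (0.09 log units; that floor lies within the scatter).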

Compound 4, half-maximal cytotoxic concentration: > 1790000 nM
Compound 4: a limit, no number; the forecaster's own chance of this, stated with the estimate: 50%; at least 1.1-fold (0.07 log units) between middle value and limit.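

Among the compounds shown here, compound 1 and compound 4 each give only a limit in this assay, so no step between them can be read. The compounds shown leave open whether 3-methylphenyl in place of pyridin-4-yl on a carbonyl carbon changes this read-out at all.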